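Quinolin-8-yl in Place of Naphthalen-1-yl on the Piperazine

A few compounds are considered here, and "the series" means these few. Any claim that something is new, unique, unknown or untested is made for them only; others in the source may bear on it.

Measured compounds:
Compound 1, `O=C1c2ccccc2S(=O)(=O)N1CCCCCCN1CCN(c2ccccc2F)CC1`: 1620 nM
Compound 2, `O=C1c2ccccc2S(=O)(=O)N1CCCCCCN1CCN(c2ccc(Cl)c(Cl)c2)CC1`: 132 nM
Compound 3, `O=C1c2ccccc2S(=O)(=O)N1CCCCCCN1CCN(c2cccc3ccccc23)CC1`: 157 nM

All three compounds share one core and differ only in the aryl group on the amine nitrogen of the saturated ring. In an ADME assay on HEK293 cells for displacement of a labelled ligand from 5-hydroxytryptamine receptor 6 (Homo sapiens), read by radioligand binding, with a stated time of 1 h (a higher number here means a weaker inhibitor, a lower number a stronger inhibitor), compound 1 gives 1620 nM. Compound 3 stands second highest of the three numbers; its nearest neighbour is compound 2, and that gap, a 1.2-fold higher number from compound 2 to compound 3 (0.08 log units; within the scatter), lies within the scatter, so no order between them can be read. Its furthest neighbour is compound 1: a 10-fold lower number from compound 1 to compound 3 (1.01 log units; beyond the scatter), a large step, matched in size by a 12-fold lower number from compound 1 to compound 2 (1.09 log units; beyond the scatter).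

Compound 4, `O=C1c2ccccc2S(=O)(=O)N1CCCCCCN1CCN(c2cccc3cccnc23)CC1`, is not yet measured. It differs from compound 3 in one place: quinolin-8-yl in place of naphthalen-1-yl on an amine nitrogen in a ring. Among the measured compounds shown here, no measured step shows the effect of this nitrogen in the second ring; the two large steps both concern the move away from the 2-fluorophenyl of compound 1 and bear only indirectly, while the comparison between compound 2 and compound 3 shows that two different bicyclic or dichlorinated aryl groups gave numbers within the scatter. The writer therefore expects for compound 4 a step of a 1.3-fold higher number from compound 3 to compound 4 (0.11 log units; within the scatter), that is, none beyond the scatter in this assay. Compound 4 is estimated at 200 nM, with a range from 60 nM to 700 nM.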

Compound 4, inhibition constant: 1720 nM
Estimate against measurement, compound 4: 8.6-fold (0.93 log units) below; measured number outside the range, above it.
By their numbers in this assay, from the lowest: compounds 2 and 3 (each within the scatter of the next); then compounds 1 and 4 (each within the scatter of the next).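

At this position in this assay, a two-ring aromatic group alone does not secure the lower numbers: quinolin-8-yl in place of naphthalen-1-yl keeps the heavy-atom count and brings in a ring nitrogen, yet it gives an 11-fold higher number from compound 3 to compound 4 (1.04 log units; beyond the scatter), a large step. Set against 3,4-dichlorophenyl, the same group gives a 13-fold higher number from compound 2 to compound 4 (1.11 log units; beyond the scatter), also large, whereas against 2-fluorophenyl it gives a 1.1-fold higher number from compound 1 to compound 4 (0.03 log units; within the scatter), within the scatter, so quinolin-8-yl and 2-fluorophenyl cannot be told apart here even though only one of them has a second ring. No measurement at hand bears on what lies behind the large step from naphthalen-1-yl to quinolin-8-yl.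

The compounds shown leave open whether a quinolin-5-yl or isoquinolin-5-yl group on the same amine nitrogen would give a number that stays with compound 4 or with compound 3. They also leave open whether the step between naphthalen-1-yl and quinolin-8-yl would hold with a butyl chain in place of the chain in the shared core.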